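The source may hold more compounds than are shown below. What is called first, only, known or untested is meant among the compounds shown, and "the series" means these compounds.

Of the compounds shown here, two have so far been measured in an assay on HEK293 cells for inhibition of Voltage-dependent N-type calcium channel subunit alpha-1B (Homo sapiens), read by fluorescence and calcium flux, with a stated time of 5 min; on this read-out lower numbers stand for stronger inhibition and higher numbers for weaker inhibition. Compound 1 `COc1ccccc1-n1nc(C2CC(C)(C)OC(C)(C)C2)cc1-c1ccnc(Cl)c1` gives 11 nM in this assay, and compound 2 `COc1ccccc1-n1nc([C@H]2C[C@@H](C)O[C@@H](C)C2)cc1-c1ccc(Cl)cc1` gives 3 nM, the lower of the two numbers by a margin beyond the usual scatter. Compound 3 `COc1ccccc1-n1nc(C2CC(C)(C)OC(C)(C)C2)cc1-c1ccc(Cl)cc1` has not yet been measured; it differs from compound 2 by 2,2,6,6-tetramethyloxan-4-yl in place of 2,6-dimethyloxan-4-yl on an aromatic carbon. Among the compounds with values here, no measured pair isolates this change, so its size is uncertain. Compound 3 is expected to give 6 nM, with a range from 2 nM to 20 nM. This estimate implies a step of a 2.0-fold higher number from compound 2 to compound 3 (0.30 log units; within the scatter), a small weakening that may not exceed the scatter.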

Compound 3, half-maximal inhibitory concentration: 1 nM
Compound 3: the middle estimate sits 6.0-fold (0.78 log units) above what was measured; measured number below the stated range.
By their numbers in this assay, from the lowest: compound 3; then compound 2; then compound 1.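

In this assay, putting 2,2,6,6-tetramethyloxan-4-yl in place of 2,6-dimethyloxan-4-yl on this aromatic carbon gives a 3.0-fold lower number from compound 2 to compound 3 (0.48 log units; beyond the scatter) and so improves the read-out, showing that the larger group is accepted at this position. With that group held constant, 4-chlorophenyl in place of 2-chloropyridin-4-yl gives an 11-fold lower number from compound 1 to compound 3 (1.04 log units; beyond the scatter) on the other side of the ring. Nothing given here explains either step. As far as these compounds go, it remains open how cyclohexyl or unsubstituted oxan-4-yl would read at this position, and how other stereoisomers of 2,6-dimethyloxan-4-yl would compare.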